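The source may report more compounds than this note shows. Statements on the series, on what has been measured and on what is new or still open speak of the compounds shown alone.

Among the compounds with values here, compound 2 `COc1nc(C)c(Nc2nc(Cl)cn([C@H](COC(=O)Nc3cccc(C#N)c3)C3CC3)c2=O)cc1C` stands lowest of the two numbers so far in an assay on frontal cortex for displacement of a labelled ligand from corticotropin-releasing factor receptor 1 (Rattus norvegicus), with a stated time of 2 h; a lower number here means a stronger inhibitor, a higher number a weaker inhibitor: compound 2 gives 1.3 nM, whereas compound 1 `COc1nc(C)c(Nc2nc(Cl)cn([C@H](COC(C)=O)C3CC3)c2=O)cc1C` gives 5.3 nM. Within the data shown here, the one measured step, a 4.1-fold lower number from compound 1 to compound 2 (0.61 log units; beyond the scatter), concerns the group on the carbonyl carbon and not the aromatic ring now in question. Compound 3 `COc1nc(C)c(Nc2nc(Cl)cn([C@H](COC(=O)Nc3cccnc3)C3CC3)c2=O)cc1C` differs from compound 2 only in that ring: pyridin-3-yl in place of 3-cyanophenyl on an amide-type nitrogen. Among the measured compounds shown here, no measured step exchanges one aromatic ring for another on this amide-type nitrogen, so nothing recorded bears directly on the change; the single step from compound 1 to compound 2 shows only that this end of the molecule can be varied while the number stays low. For compound 3 the step of a 1.5-fold higher number from compound 2 to compound 3 (0.19 log units; within the scatter) is therefore expected to remain within the scatter, with no direction that can be argued from the data. Compound 3 is estimated at 2 nM, with a range from 0.7 nM to 6 nM.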

Compound 3, half-maximal inhibitory concentration: 10 nM
For compound 3 the middle estimate is 5.0-fold (0.70 log units) below the measured one; measured number outside the range, above it.
By their numbers in this assay, from the lowest: compound 2; then compounds 1 and 3 (each within the scatter of the next).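

In this assay the aromatic ring on the amide-type nitrogen proves not to be freely exchangeable: the step of a 7.7-fold higher number from compound 2 to compound 3 (0.89 log units; beyond the scatter) shows that this position does respond to the change from 3-cyanophenyl to pyridin-3-yl. Within the data shown here, the lower number reached with the (3-cyanophenyl)amino group is not kept with the (pyridin-3-yl)amino group, since the step of a 1.9-fold higher number from compound 1 to compound 3 (0.28 log units; within the scatter) leaves compound 3 no different from the compound with methyl on the carbonyl carbon. Nothing measured here explains the gap between the two rings.

The compounds shown leave open whether the nitrile or the all-carbon ring goes with the lower number of compound 2. A plain phenyl group on the same nitrogen would separate the two, and a pyridin-3-yl ring carrying a nitrile would test whether the ring nitrogen and the nitrile act independently.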